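Notes on compound 3: one fluoro less on the sulfonyl aryl

The source may report more compounds than this note shows. Statements on the series, on what has been measured and on what is new or still open speak of the compounds shown alone.

Of the compounds shown here, two have been measured in a functional assay on HepG2 cells (Homo sapiens) for cytotoxicity, read by MTT assay, with a stated time of 72 h; a higher number here means a weaker inhibitor, a lower number a stronger inhibitor. Compound 1 `CN(C)Cc1ccc(-c2ccnc3ccc(-c4cnc(Cl)c(NS(=O)(=O)c5ccc(F)cc5F)c4)cc23)cc1` gives 3860 nM. Compound 2 `O=S(=O)(Nc1cc(-c2ccc3nccc(-c4ccc(Cn5cncn5)cc4)c3c2)cnc1Cl)c1ccc(F)cc1F` gives 2040 nM. Among the compounds with values here, the single measured step, a 1.9-fold lower number from compound 1 to compound 2 (0.28 log units; within the scatter), is the only comparison available. Compound 2 stands at the lowest of the two numbers, but its nearest neighbour, compound 1, lies within the scatter, so no order between the two is claimed.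

Compound 3 `O=S(=O)(Nc1cc(-c2ccc3nccc(-c4ccc(Cn5cncn5)cc4)c3c2)cnc1Cl)c1ccc(F)cc1` differs from compound 2 by hydrogen in place of fluoro on an aromatic carbon, in other words (2,4-difluorophenyl)sulfonyl becomes (4-fluorophenyl)sulfonyl. Within the data shown here, no measured step touches this part of the molecule: the one step that exists changes the group on the saturated chain carbon at the other end of the shared core and stayed within the scatter. The data give no direction for the present change, and no step beyond the scatter is expected in this assay. Compound 3 is therefore estimated at 2000 nM, within 800 nM to 5000 nM, which means an expected step of a 1.0-fold lower number from compound 2 to compound 3 (0.01 log units; within the scatter).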

Compound 3, half-maximal inhibitory concentration: 9600 nM
Estimate against measurement, compound 3: 4.8-fold (0.68 log units) below; the measured number lies above the stated range.
By their numbers in this assay, from the lowest: compounds 2 and 1 (each within the scatter of the next); then compound 3.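

In this assay, within the data shown here, the change from (2,4-difluorophenyl)sulfonyl to (4-fluorophenyl)sulfonyl gives a 4.7-fold higher number from compound 2 to compound 3 (0.67 log units; beyond the scatter) and is the first step to lie beyond the scatter, though it is modest in size. The sulfonyl aryl therefore counts as a place where this read-out responds to the loss of one heavy atom, a fluoro on an aromatic carbon ortho to a large group and meta to a fluoro group, whereas the exchange of dimethylamino for 1H-1,2,4-triazol-1-yl on the saturated chain carbon gave only a 1.9-fold lower number from compound 1 to compound 2 (0.28 log units; within the scatter) and separated nothing. No measurement at hand accounts for the size or direction of this step.

Still open, as far as these compounds go, is whether chloro, methyl or methoxy in place of this fluoro would keep the number close to that of compound 2, and whether the remaining fluoro of the 4-fluorophenyl group matters in the same way. Also open, from the compounds shown here alone, is whether the same loss of fluoro gives a step of similar size when dimethylamino, as in compound 1, stands at the other end of the shared core.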